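Sulfonyl group exchange and expected cytotoxicity

The source may hold more compounds than are shown below. What is called first, only, known or untested is meant among the compounds shown, and "the series" means these compounds.

Measured compounds:
compound 1, `Cc1cc(/C=C/C#N)cc(C)c1Oc1ccnc(Nc2ccc(CN3CCCN(S(=O)(=O)C(C)C)CC3)cc2)n1`, with 4640 nM
compound 2, `CCS(=O)(=O)N1CCN(Cc2ccc(Nc3nccc(Oc4c(C)cc(/C=C/C#N)cc4C)n3)cc2)CC1`, with 4600 nM

In an ADME assay on MT4 cells (Homo sapiens) for cytotoxicity, read by MTT assay (on this read-out lower numbers stand for higher toxicity in this test and higher numbers for lower toxicity in this test), compound 1 gives 4640 nM, and compound 2 gives 4600 nM; the two numbers lie within the usual scatter of each other, so neither can be called the more or less toxic of the pair. Compound 3, `Cc1cc(/C=C/C#N)cc(C)c1Oc1ccnc(Nc2ccc(CN3CCCN(S(=O)(=O)N(C)C)CC3)cc2)n1`, has not been measured in this assay. It differs from compound 1 in one place: dimethylamino in place of isopropyl on a sulfonyl sulfur. Among the compounds with values here, no measured pair shows this exchange, so no size can be read for it from the data. The two measured compounds, which differ elsewhere in the sulfonyl region, give numbers that agree, which suggests a small step here. The step of a 1.0-fold lower number from compound 1 to compound 3 (0.01 log units; within the scatter) is therefore expected to stay within the scatter, in no particular direction. Compound 3 is estimated to give 4500 nM, with a range from 2000 nM to 10000 nM.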

Compound 3, half-maximal cytotoxic concentration: 3900 nM
Compound 3: middle estimate off by 1.2-fold (0.06 log units), on the high side; low and high end bracket the measured number.
By their numbers in this assay, from the lowest: compounds 3, 2 and 1 (each within the scatter of the next).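

In this assay, replacing isopropyl with dimethylamino gives a 1.2-fold lower number from compound 1 to compound 3 (0.08 log units; within the scatter), the first size read directly for a single exchange on this sulfonyl sulfur. At this place, whose other neighbour is a sulfonamide nitrogen in a ring, one group of three heavy atoms can therefore replace the other, with a nitrogen entering where a carbon stood, without the read-out leaving the scatter. No measurement here accounts for this outcome, so it remains an observation without an assigned cause.

The compounds shown leave open whether a group of another kind on this sulfur, such as a longer alkyl chain, a primary amine or a carboxylic acid, would also stay within the scatter of compound 1. They also leave open how far such a group could differ from isopropyl before the read-out moved beyond that scatter.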